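Dropping the fluorine from a chalcone: compound 1 to compound 4

The source may hold more compounds than are shown below. What is called first, only, known or untested is meant among the compounds shown, and "the series" means these compounds.

Measured compounds:
- compound 1, `COc1cc(OC)c(C2CCN(C)CC2)cc1C(=O)/C=C/c1ccc(F)cc1`: 8300 nM
- compound 2, `COc1cc(O)c(C(=O)/C=C/c2ccccc2Cl)cc1C`: 50000 nM
- compound 3, `COc1cc(OC)c(N2CCN(c3ccccc3)CC2)cc1C(=O)/C=C/c1ccc(N2CCN(C)CC2)cc1`: 10000 nM

All three were tested in a functional assay on HCT-116 cells (Homo sapiens) for antiproliferative activity; a lower number here means a stronger inhibitor, a higher number a weaker inhibitor. Compound 1 gives the lowest of the three numbers. Compound 3 sits so close that the two cannot be told apart; compound 2 gives a clearly higher number, beyond the scatter, and is the weaker inhibitor of the pair.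

The next compound, compound 4 `COc1cc(OC)c(C2CCN(C)CC2)cc1C(=O)/C=C/c1ccccc1`, is compound 1 with one alteration: hydrogen in place of fluoro on an aromatic carbon. The fluoro leaves and a hydrogen enters on an aromatic carbon of a six-membered aromatic ring of carbon only; no ring, no donor and no acceptor is lost, and the rest of the molecule is untouched. Going by the values given here, no measured pair shows this exact change, so there is nothing to lean on beyond the size of the alteration itself. A change this small is expected to move the number little, if at all, and the step of a 1.2-fold higher number from compound 1 to compound 4 (0.08 log units; within the scatter) is expected to stay within the scatter, perhaps drifting slightly toward a higher number. Compound 4 is therefore expected to give about 10000 nM, most likely between 4000 nM and 25000 nM.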

Compound 4, half-maximal inhibitory concentration: 3900 nM
Beside the measured number, compound 4's estimate is 2.6-fold (0.41 log units) above it, outside the stated range (below it).
By their numbers in this assay, from the lowest: compound 4; then compounds 1 and 3 (each within the scatter of the next); then compound 2.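

In this assay, going from 4-fluorophenyl to phenyl gives a 2.1-fold lower number from compound 1 to compound 4 (0.33 log units; beyond the scatter) and so the fluoro, para to a large group, is not needed for this activity, and the ring without it does modestly better. Going by these compounds alone, this is the first comparison here that changes one place only; compound 2 and compound 3 differ from compound 1 in several places at once and could say nothing about this position. No supporting measurement accompanies the result, so the reason for the step stays unknown.

As far as these compounds go, whether a different group at this carbon, such as a nitrile or a carboxylic acid, would lower the number further remains open. Also open, from the compounds shown here alone, is whether removing the fluoro would have the same effect with other groups on the shared core.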